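Moving the chlorines: compound 2 to compound 3

The source may hold more compounds than are shown below. What is called first, only, known or untested is meant among the compounds shown, and "the series" means these compounds.

Measured so far in a functional assay on Jurkat cells (Homo sapiens); a higher number here means a weaker inhibitor, a lower number a stronger inhibitor:
- compound 1 `Cc1ccccc1CNC(=O)C(=O)N[C@@H](C)C(=O)N[C@@H](CC(=O)O)C(=O)COc1c(F)c(F)cc(F)c1F`: 52 nM
- compound 2 `C[C@H](NC(=O)C(=O)NCc1c(Cl)cccc1Cl)C(=O)N[C@@H](CC(=O)O)C(=O)COc1c(F)c(F)cc(F)c1F`: 110 nM

Of the two measured compounds, compound 2 has the higher number at 110 nM, making it the weaker inhibitor. Next is compound 3 `C[C@H](NC(=O)C(=O)NCc1cc(Cl)cc(Cl)c1)C(=O)N[C@@H](CC(=O)O)C(=O)COc1c(F)c(F)cc(F)c1F`, which keeps the shared core and differs only in its aryl group: 3,5-dichlorophenyl in place of 2,6-dichlorophenyl on a saturated chain carbon bound to an amide-type nitrogen. The 3,5-dichlorophenyl group replaces the 2,6-dichlorophenyl group on a saturated chain carbon bound to an amide-type nitrogen.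

Among the measured compounds shown here, only one measured step bears on this change: a 2.1-fold higher number from compound 1 to compound 2 (0.33 log units; beyond the scatter). That modest step, at the same place, shows that the number can move when this aryl group changes. For the measured compounds named here, no measured compound carries the 3,5-dichlorophenyl group, and the data give no firm direction. Given the size of a 2.1-fold higher number from compound 1 to compound 2 (0.33 log units; beyond the scatter), a step no larger than that modest one is expected in this assay, leaning slightly towards a higher number. The expected step is a 1.3-fold higher number from compound 2 to compound 3 (0.10 log units; within the scatter). For compound 3 the estimated value is 140 nM, with an expected range of 45 nM to 420 nM.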

Compound 3, half-maximal inhibitory concentration: 23 nM
Compound 3: the middle estimate sits 6.1-fold (0.78 log units) above what was measured, outside the stated range (below it).
By their numbers in this assay, from the lowest: compound 3; then compound 1; then compound 2.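

Same atoms, same ring: moving the two chlorines alone gives a 4.8-fold lower number from compound 2 to compound 3 (0.68 log units; beyond the scatter) in this assay, so this position responds to where the chlorines stand on the phenyl ring and not only to which group is present. The 3,5-dichlorophenyl group also gives a lower number than the 2-methylphenyl group, with a 2.3-fold lower number from compound 1 to compound 3 (0.35 log units; beyond the scatter), which leaves compound 3 as the strongest inhibitor of the three, since its steps to both others are beyond the scatter, and shows that the weaker result for the 2,6-dichlorophenyl group does not extend to dichlorophenyl groups in general. Nothing in the available data accounts for this difference between the two chlorine arrangements.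

Open, from the compounds shown here alone, is whether a single chlorine on the phenyl ring would hold the lower number, or whether bromine, a methoxy group or a nitrile could stand in for the chlorines. Also open, going by these compounds, is how a longer chain in place of the saturated chain carbon bound to an amide-type nitrogen would read with the 3,5-dichlorophenyl group kept.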